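The source may hold more compounds than are shown below. What is called first, only, known or untested is meant among the compounds shown, and "the series" means these compounds.

Measured in an ADME assay on cells (Fibroblast, Gallus gallus) for cytotoxicity, read by CCK-8 assay, with a stated time of 48 h; on this read-out higher numbers stand for lower toxicity in this test and lower numbers for higher toxicity in this test:
- Compound 1 `CCC(CC)O[C@@H]1C=C(C(=O)O)C[C@H](NCc2ccc(OC(C)C)cc2)[C@H]1NC(C)=O`: > 200000 nM, a limit.
- Compound 2 `CCC(CC)Oc1ccc(CN[C@H]2CC(C(=O)O)=C[C@@H](OC(CC)CC)[C@@H]2NC(C)=O)cc1`: > 200000 nM, a limit.
- Compound 3 `CCC(CC)O[C@@H]1C=C(C(=O)O)C[C@H](NCc2ccc(SC3CCCC3)cc2)[C@H]1NC(C)=O`: > 200000 nM, a limit.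

Compound 3 gives > 200000 nM, which is a limit of this assay and not a number. It has no rank among the three, since what they share is the limit of > 200000 nM in this assay, at which 3 of the 3 values shown sit.

Compound 4 `CCC(CC)O[C@@H]1C=C(C(=O)O)C[C@H](NCc2ccc(-c3cc4ccccc4s3)cc2)[C@H]1NC(C)=O` differs from compound 3 in one group: 1-benzothiophen-2-yl in place of cyclopentylsulfanyl on an aromatic carbon. In words, 1-benzothiophen-2-yl comes in place of cyclopentylsulfanyl on an aromatic carbon.

Among the compounds with values here, three measured steps bear on this change, all of them swaps of a group on that aromatic ring. The closest is a step that the two limits leave unreadable from compound 2 to compound 3. The others are a step that the two limits leave unreadable from compound 1 to compound 3 and a step that the two limits leave unreadable from compound 1 to compound 2. None of them gives a size or a direction to carry over, and none of the three compounds carries 1-benzothiophen-2-yl.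

With compound 3 at > 200000 nM, the expectation is no step beyond the scatter, although a readable, lower number remains possible for a group not yet tested. The estimated change is a number no higher from compound 3 to compound 4 (the limit leaves the size open). For compound 4 the expected value is 200000 nM, with an estimated range from 90000 nM to 300000 nM.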

Compound 4, half-maximal cytotoxic concentration: > 200000 nM
Compound 4 was reported as a limit; the forecaster's own chance of this, stated with the estimate: 75%; the middle value sits exactly at the limit.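

In this assay compound 4 gives > 200000 nM, a limit of the assay and not a number. Within the data shown here, no step between compound 4 and compound 1, compound 2 or compound 3 can be read, because all four share the same limit: the limit of > 200000 nM in this assay, at which 4 of the 4 values shown sit. Where the true value of each compound lies, and whether the groups on the aromatic ring differ at all in this test, stays open.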